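From 2-methylphenyl to 3-bromophenyl on the shared core

The source may report more compounds than this note shows. Statements on the series, on what has been measured and on what is new or still open speak of the compounds shown alone.

In a functional assay on LoVo cells (Homo sapiens) for inhibition, read by MTT assay, with a stated time of 24 h (a higher number here means a weaker inhibitor, a lower number a stronger inhibitor), compound 1 `CC1(C)[C@H]2CC[C@]1(C)N(Cc1cn(-c3ccccc3)nn1)C(=O)C2` gives 50 nM and compound 2 `Cc1ccccc1-n1cc(CN2C(=O)C[C@@H]3CC[C@@]2(C)C3(C)C)nn1` gives 80 nM, so compound 2 stands within the scatter of compound 1. Among the measured compounds shown here, the only measured step, a 1.6-fold higher number from compound 1 to compound 2 (0.20 log units; within the scatter), is methyl in place of hydrogen on an aromatic carbon. Compound 3 `CC1(C)[C@H]2CC[C@]1(C)N(Cc1cn(-c3cccc(Br)c3)nn1)C(=O)C2` has 3-bromophenyl in place of 2-methylphenyl on an aromatic nitrogen. For the measured compounds named here, no measured compound carries bromine, so this single small step is the only guide, and no change beyond the scatter is expected. The estimated change is a 1.3-fold lower number from compound 2 to compound 3 (0.12 log units; within the scatter). The expected value for compound 3 is 60 nM, with an estimated range of 20 nM to 180 nM.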

Compound 3, half-maximal inhibitory concentration: 30 nM
Beside the measured number, compound 3's estimate is 2.0-fold (0.30 log units) above it; the measured number falls inside the stated range.
By their numbers in this assay, from the lowest: compounds 3, 1 and 2 (each within the scatter of the next, the first and the last beyond it).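

In this assay, among the compounds shown here, the change from 2-methylphenyl to 3-bromophenyl on the aromatic nitrogen gives the first step beyond the scatter: a 2.7-fold lower number from compound 2 to compound 3 (0.43 log units; beyond the scatter). Against the plain phenyl of compound 1, bromo in place of hydrogen stays within the scatter, with a 1.7-fold lower number from compound 1 to compound 3 (0.22 log units; within the scatter), so this step alone does not establish a benefit from bromine. Nothing measured here bears on the cause of either step. Going by these compounds, whether an amine or a carboxylic acid in place of the bromo would retain the activity of compound 3 stays open.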